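Ring amine substituents on the shared core

The compounds below may be only part of what the source reports. "The series", "measured", "known", "first", "only" and "open" are said of these compounds alone.

Measured so far, with the read-out of a functional assay on HCC827 cells (Homo sapiens) for antiproliferative activity, read by MTT assay, with a stated time of 72 h; a lower number here means a stronger inhibitor, a higher number a weaker inhibitor:
compound 1 `CN1CCN(c2ccc(Nc3ncc4nc(Nc5ccc(F)cc5)n([C@H]5CCCN(S(=O)(=O)C6CC6)C5)c4n3)cc2)CC1` gives 8.6 nM
compound 2 `CN1CCN(c2ccc(Nc3ncc4nc(Nc5ccc(F)cc5)n([C@H]5CCCN(C(=O)CO)C5)c4n3)cc2)CC1` gives 1.8 nM
compound 3 `CN1CCN(c2ccc(Nc3ncc4nc(Nc5ccccc5)n([C@H]5CCN(S(C)(=O)=O)C5)c4n3)cc2)CC1` gives 17 nM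

Compound 1 stands second highest of the three numbers; compound 3 lies within the scatter of it, while compound 2 sits well below it, a step of a 4.8-fold lower number from compound 1 to compound 2 (0.68 log units; beyond the scatter).

Compound 4 `CCOC(=O)CN1CC[C@H](n2c(Nc3ccc(F)cc3)nc3cnc(Nc4ccc(N5CCN(C)CC5)cc4)nc32)C1` is unmeasured. It differs from compound 1 by 1-((ethoxycarbonyl)methyl)pyrrolidin-3-yl in place of 1-(cyclopropylsulfonyl)piperidin-3-yl on an aromatic nitrogen. Going by the values given here, only the step from compound 1 to compound 2 touches the same amine nitrogen in a ring, and it replaced the sulfonyl with a carbonyl group; compound 4 instead removes the sulfonyl for an ethoxycarbonylmethyl chain and shrinks the ring. Among the compounds with values here, no measured step covers that combination, so a change within the scatter, or a small one in either direction, is expected: a 1.2-fold higher number from compound 1 to compound 4 (0.07 log units; within the scatter).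

Compound 4 is estimated at 10 nM, between 3 nM and 35 nM.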

Compound 4, half-maximal inhibitory concentration: 1810 nM
Estimate against measurement, compound 4: 180-fold (2.26 log units) below; the measured number lies above the stated range.
By their numbers in this assay, from the lowest: compound 2; then compounds 1 and 3 (each within the scatter of the next); then compound 4.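

In this assay, going by these compounds alone, the group on the aromatic nitrogen proves able to carry a large loss: 1-((ethoxycarbonyl)methyl)pyrrolidin-3-yl gives a 210-fold higher number from compound 1 to compound 4 (2.32 log units; beyond the scatter) and a 1000-fold higher number from compound 2 to compound 4 (3.00 log units; beyond the scatter) as well, whereas the only earlier step on the ring amine nitrogen was modest. The swap puts a chain on that nitrogen in place of a directly attached sulfonyl or carbonyl, and a five-membered ring in place of a six-membered one. Nothing at hand accounts for the loss.

The shares of ring size and chain remain unresolved. Open too, going by these compounds, is how a carboxylic acid in place of the ethyl ester, or the same chain on the six-membered ring, would read.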